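This account rests on a few compounds, and the source may have more. Where it says the series, first, only, none or still open, it means among the compounds named here.

Working notes on the series. Compound 1, `COC(=O)/C=C/C(=O)c1ccccc1`, gives 2.24 in a physicochemical assay for lipophilicity; on this read-out lower numbers stand for lower lipophilicity and higher numbers for higher lipophilicity. Compound 2, `O=C(O)/C=C/C(=O)c1ccccc1`, gives 1.94 in this assay. Within the data shown here, on these two numbers compound 2 stands lowest, its nearest neighbour being compound 1; the single measured step, a number 0.30 log units lower from compound 1 to compound 2 (within the scatter), lies within the scatter, so the two values cannot be ordered. Compound 3, `O=C(O)/C=C/C(=O)c1ccc(-c2ccccc2)cc1`, is yet to be measured in this assay. It differs from compound 2 by phenyl in place of hydrogen on an aromatic carbon. Among the measured compounds shown here, no measured step involves a phenyl entering on an aromatic carbon; the step from compound 1 to compound 2 concerns a different change and offers no direct guide. The expectation rests on the structural change alone, and the expected step is a number 1.86 log units higher from compound 2 to compound 3 (beyond the scatter), upward and beyond the scatter. For compound 3 the estimated value in this assay is 3.8, with an expected range from 3.2 to 4.4.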

Compound 3, partition coefficient: 3.9
Compound 3: the middle estimate sits 0.10 log units below what was measured; measured number inside the range.
By their numbers in this assay, from the lowest: compounds 2 and 1 (each within the scatter of the next); then compound 3.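

In this assay, among these compounds, phenyl in place of hydrogen on an aromatic carbon, para to a group of 7 heavy atoms, gives a number 1.96 log units higher from compound 2 to compound 3 (beyond the scatter), the only step that lies beyond the scatter. This aromatic carbon is therefore a place where a single change clearly separates two compounds, whereas the change on the oxygen next to a carbonyl group left two values that cannot be ordered. No measurement shown here explains the size of this step.

Open, as far as these compounds go, is whether a smaller group on the same aromatic carbon, such as methyl, chlorine or an amine, would give a step of similar size. Also open, from the compounds shown here alone, is whether phenyl at this place would give a similar step on the core of compound 1.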